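The source may hold more compounds than are shown below. What is called first, only, known or untested is meant among the compounds shown, and "the series" means these compounds.

Measured so far:
- compound 1, `CC(C)(C)OC(=O)N1CCN(C(=S)SCc2cn(Cc3cc(=O)oc4cc(O)ccc34)nn2)CC1`: 4960 nM
- compound 2, `COc1ccc(Cn2cc(CSC(=S)N3CCN(C(=O)OCc4ccccc4)CC3)nn2)cc1`: 23800 nM

In a functional assay on MGC-803 cells (Homo sapiens) for inhibition, read by MTT assay, with a stated time of 72 h (on this read-out higher numbers stand for weaker inhibition and lower numbers for stronger inhibition), compound 2 gives 23800 nM, the highest of the two numbers in hand; compound 1 stands at 4960 nM, and the gap between the two lies beyond the usual scatter. Compound 1 and compound 2 differ in more than one place, so their gap cannot be assigned to any single change.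

Compound 3, `O=C(OCc1ccccc1)N1CCN(C(=S)SCc2cn(Cc3ccccc3F)nn2)CC1`, is not yet measured. It differs from compound 2 in one place: 2-fluorophenyl in place of 4-methoxyphenyl on a saturated chain carbon bound to an aromatic nitrogen. Going by the values given here, no pair of measured compounds shows this change in isolation, so there is no step to lean on. The expectation is a step from compound 2 to compound 3 of a 1.3-fold lower number from compound 2 to compound 3 (0.12 log units; within the scatter), not clearly beyond the scatter in either direction. Compound 3 is expected to give 18000 nM in this assay, within a range of 6000 nM to 50000 nM.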

Compound 3, half-maximal inhibitory concentration: 5060 nM
Compound 3: middle estimate off by 3.6-fold (0.55 log units), on the high side, outside the stated range (below it).
By their numbers in this assay, from the lowest: compounds 1 and 3 (each within the scatter of the next); then compound 2.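

In this assay, the aryl group on a saturated chain carbon bound to an aromatic nitrogen proves able to shift the read-out on its own: 2-fluorophenyl in place of 4-methoxyphenyl gives a 4.7-fold lower number from compound 2 to compound 3 (0.67 log units; beyond the scatter), with the rest of the molecule unchanged. Going by these compounds alone, this is the first change that can be read in isolation, but it rests on a single pair and swaps both the substituent and its place on the ring, so neither can be credited separately. No measured property accounts for the step.

Open, going by these compounds, is whether the loss of 4-methoxyphenyl or the arrival of 2-fluorophenyl carries the step, which plain phenyl would help to settle. Also open, on these data alone, are how a carboxylic acid or an aminomethyl group on that ring would read, and whether the step holds with the other end of the molecule changed.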